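The source may report more compounds than this note shows. Statements on the series, on what has been measured and on what is new or still open speak of the compounds shown alone.

Measured compounds in an ADME assay on HT-29 cells (Homo sapiens) for cytotoxicity, read by MTT assay, with a stated time of 72 h; a higher number here means a weaker inhibitor, a lower number a stronger inhibitor:

Compound 1 `COc1ccc(C2=C(c3cc(OC)c(OC)c(OC)c3)C(=O)C(O)C2)cc1`. In this assay compound 1 reaches only the limit < 1 ug/mL.

Compound 2 `COc1ccc(C2=C(c3cc(OC)c(OC)c(OC)c3)CC(O)C2=O)cc1[N+](=O)[O-]`. In this assay compound 2 reaches only the limit > 100 ug/mL.

Compound 3 `COc1ccc(C2=C(c3cc(OC)c(OC)c(OC)c3)C(=O)C(O[SiH2]C(C)(C)C)C2)cc1`. In this assay compound 3 gives 5 ug/mL.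

Compound 3 differs from compound 1 by a group of 5 heavy atoms (4 carbon, 1 silicon; no ring) in place of a hydrogen atom, on an oxygen on a saturated carbon. That change produced an at least 5.0-fold higher number from compound 1 to compound 3 (0.69 log units; beyond the scatter). The true size of this step is open at its lower end because compound 1 sits at the limit of < 1 ug/mL in this assay, at which 1 of the 3 values shown sits.

Compound 2 and compound 1 share neither a single-point change nor a small edit; the difference between the two cores is not broken down here. Compound 2 sits at the limit of > 100 ug/mL in this assay, at which 1 of the 3 values shown sits, so its own value is a limit and not a number.

Compound 4 `COc1ccc(C2=C(c3cc(OC)c(OC)c(OC)c3)CC(O[SiH2]C(C)(C)C)C2=O)cc1[N+](=O)[O-]` has not yet been measured in this assay. It differs from compound 2 by a group of 5 heavy atoms (4 carbon, 1 silicon; no ring) in place of a hydrogen atom, on an oxygen on a saturated carbon, which is the same change as that from compound 1 to compound 3: both place lines read alike.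

For the step from compound 2 to compound 4 in this assay the expectation is a step that the limit leaves unreadable from compound 2 to compound 4, set beside the earlier at least 5.0-fold higher number from compound 1 to compound 3 (0.69 log units; beyond the scatter). This rests on two things: the measured step from compound 1 to compound 3, and the fact that compound 2 already stands at a limit, so a further weakening would most likely again be reported as a limit rather than a number. Compound 4 is therefore estimated at 180 ug/mL, expected to fall between 70 ug/mL and 500 ug/mL.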

Compound 4, half-maximal inhibitory concentration: > 100 ug/mL
Compound 4 ended at the assay's limit; the forecaster's own chance of this, stated with the estimate: 85%; the middle value lies beyond the limit too.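

In this assay compound 4 gives > 100 ug/mL as a limit and not a number. Compound 2 also gives > 100 ug/mL as a limit. For the compounds shown here, no step from compound 2 to compound 4 can be read, since both stand at the same limit: the limit of > 100 ug/mL in this assay, at which 2 of the 4 values shown sit.

The compounds shown leave open whether the group of 5 heavy atoms in place of the hydrogen atom changes the value on the core of compound 2 at all.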